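A few compounds are considered here, and "the series" means these few. Any claim that something is new, unique, unknown or untested is made for them only; others in the source may bear on it.

In a functional assay on cells (Tumor Cell line, Homo sapiens) for antiproliferative activity (on this read-out higher numbers stand for weaker inhibition of growth and lower numbers for stronger inhibition of growth), compound 1 `Cc1ccnc2nc(-c3cccc(Cl)c3)cc(O)c12` gives 158 nM and compound 2 `Cc1ccc2c(O)cc(-c3cccc(Cl)c3)nc2n1` gives 170 nM, so these two values lie within the usual scatter of each other. Compound 3 `Cc1cccc(-c2cc(O)c3ccc(C)nc3n2)c1` keeps the core of compound 2 and differs from it in one place: methyl in place of chloro on an aromatic carbon. Among the measured compounds shown here, no measured pair shows this swap, so the estimated step in this assay is a 1.2-fold higher number from compound 2 to compound 3 (0.07 log units; within the scatter), with nothing expected beyond the scatter in either direction. Compound 3 is estimated at 200 nM, with an expected range from 70 nM to 550 nM.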

Compound 3, concentration for 50% growth inhibition: 97.7 nM
Compound 3: middle estimate off by 2.0-fold (0.31 log units), on the high side; measured number inside the range.
By their numbers in this assay, from the lowest: compounds 3, 1 and 2 (each within the scatter of the next).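

With methyl in place of chloro on this aromatic carbon, this assay shows a 1.7-fold lower number from compound 2 to compound 3 (0.24 log units; within the scatter) and so no shift that stands clear of the scatter. Among the compounds shown here, compounds 1 and 2 both carry chloro, so only this pair tests a second group here, and the position accepts methyl as well as chloro on this read-out. As far as these compounds go, whether an amine, a carboxylic acid or a longer chain would also fit at this position stays open. Nothing measured here explains why chloro and methyl give values within the scatter of each other.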